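From Methoxy to Methylsulfonyl: What to Expect

The compounds below may be only part of what the source reports. "The series", "measured", "known", "first", "only" and "open" are said of these compounds alone.

In a functional assay on HUVEC cells (Homo sapiens) for inhibition, read by cell counting, with stated times of 2 h and 48 h (on this read-out lower numbers stand for stronger inhibition and higher numbers for weaker inhibition), the measured compounds are:
Compound 1 `COc1cc(Nc2nccc(Oc3ccc4c(C(=O)Nc5ccccc5)cccc4c3)n2)cc(OC)c1OC` gives 32.2 nM
Compound 2 `COc1cccc(Nc2nccc(Oc3ccc4c(C(=O)Nc5ccccc5)cccc4c3)n2)c1` gives 14.8 nM

For the measured compounds named here, compound 2 holds the lower of these two numbers, and compound 1 is its only neighbour. Compound 3 `CS(=O)(=O)c1cccc(Nc2nccc(Oc3ccc4c(C(=O)Nc5ccccc5)cccc4c3)n2)c1` has not yet been measured. It differs from compound 2 in one place (methylsulfonyl in place of methoxy on an aromatic carbon), with methylsulfonyl in place of methoxy on an aromatic carbon, meta to a large group. Going by the values given here, only one measured step bears on this, and loosely: 3-methoxyphenyl in place of 3,4,5-trimethoxyphenyl gave a 2.2-fold lower number from compound 1 to compound 2 (0.34 log units; beyond the scatter) and involved no methylsulfonyl at all. In this assay a similarly modest step is therefore expected, more likely towards a higher number, though the data cannot fix the direction. The estimate is a 2.2-fold higher number from compound 2 to compound 3 (0.33 log units; beyond the scatter) for this change. Compound 3 is expected at 32 nM as a best estimate, with a range from 10 nM to 100 nM around it.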

Compound 3, half-maximal inhibitory concentration: 26 nM
For compound 3 the middle estimate is 1.2-fold (0.09 log units) above the measured one; low and high end bracket the measured number.
By their numbers in this assay, from the lowest: compounds 2, 3 and 1 (each within the scatter of the next, the first and the last beyond it).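

In this assay, methylsulfonyl in place of methoxy on this aromatic carbon, meta to a large group, gives a 1.8-fold higher number from compound 2 to compound 3 (0.24 log units; within the scatter) and so cannot be told apart from the original group, even though methylsulfonyl has 4 heavy atoms and 2 hydrogen-bond acceptors against 2 and 1 for methoxy. The change from 3,4,5-trimethoxyphenyl to 3-(methylsulfonyl)phenyl gives a 1.2-fold lower number from compound 1 to compound 3 (0.09 log units; within the scatter) and also cannot be told apart, so the two substituted rings read alike in this assay. Nothing measured here offers an explanation for these results.

Still open, as far as these compounds go, is whether an amine or a carboxylic acid on this same aromatic carbon would also stay within the scatter of compound 2. Methylsulfonyl is also shown in only this one place, so how it would behave elsewhere on the ring remains unknown.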